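This account rests on a few compounds, and the source may have more. Where it says the series, first, only, none or still open, it means among the compounds named here.

Of the compounds shown here, three have been measured in a functional assay on HepG2 cells (Homo sapiens) for inhibition, read by MTT assay, with a stated time of 48 h; on this read-out lower numbers stand for stronger inhibition of growth and higher numbers for weaker inhibition of growth: compound 1 `Cn1cc(C2CC(c3ccccc3)=NN2C(=O)c2cccnc2)c2ccccc21` gives 4630 nM; compound 2 `COc1ccc(C(=O)N2N=C(c3ccccc3)CC2c2cn(C)c3ccccc23)cn1` gives 3130 nM; compound 3 `COc1ccc(C2=NN(C(=O)c3cccnc3)C(c3cn(C)c4ccc(Br)cc34)C2)cc1` gives 540 nM.

Compound 3 gives the lowest number of the three. Compound 2 differs from compound 1 by methoxy in place of hydrogen on an aromatic carbon, which made a 1.5-fold lower number from compound 1 to compound 2 (0.17 log units; within the scatter). Compound 4 `COc1ccc(C2=NN(C(=O)c3cccnc3)C(c3cn(C)c4ccc(Br)cc34)C2)cc1OC` differs from compound 3 by methoxy in place of hydrogen on an aromatic carbon. This is the same kind of change, but not at the same place: in compound 2 the methoxy sits on a six-membered aromatic ring with 1 nitrogen, next to the ring nitrogen and para to a large group, whereas in compound 4 it sits on a six-membered aromatic ring of carbon only, ortho to a methoxy group and meta to a large group. The difference between the core of compound 1 and the core of compound 3 is not broken down here. For compound 4 the expected step in this assay is a 1.2-fold lower number from compound 3 to compound 4 (0.08 log units; within the scatter), because a 1.5-fold lower number from compound 1 to compound 2 (0.17 log units; within the scatter) stayed within the scatter. Compound 4 is therefore estimated at 450 nM, most likely between 200 nM and 1100 nM.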

Compound 4, concentration for 50% growth inhibition: 2450 nM
Estimate against measurement, compound 4: 5.4-fold (0.74 log units) below; measured number outside the range, above it.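

In this assay, the change from 4-methoxyphenyl to 3,4-dimethoxyphenyl gave a 4.5-fold higher number from compound 3 to compound 4 (0.66 log units; beyond the scatter). Set beside the earlier step, the same kind of change did not carry over from one core to the other: the same change on two cores in this assay, a 1.5-fold lower number (0.17 log units; within the scatter) from compound 1 to compound 2 and a 4.5-fold higher number (0.66 log units; beyond the scatter) from compound 3 to compound 4, 6.7-fold (0.83 log units) apart, beyond the scatter of two such steps This does not show what sets the two steps apart, since they differ in the ring that receives the methoxy as well as in the core, and each direction rests on a single pair.

The compounds shown leave open whether a methoxy on the ring of carbon only would give a similar step on the core of compound 1. They also leave open how a hydroxy group, a fluorine atom or an amine would behave in place of the added methoxy.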